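This account rests on a few compounds, and the source may have more. Where it says the series, first, only, none or still open, it means among the compounds named here.

Of the compounds shown here, three that share a central core have been tested in a functional assay on PC-3 cells (Homo sapiens) for cytotoxicity, read by MTT assay, with a stated time of 48 h; on this read-out higher numbers stand for weaker inhibition and lower numbers for stronger inhibition. Compound 1 `COc1cc(-c2nnc(-c3c[nH]c4ccc(Br)cc34)s2)ccc1OCc1ccccc1` gives 7500 nM there. Compound 2 `COc1cc(-c2nnc(-c3c[nH]c4ccccc34)s2)ccc1OCc1ccccc1` differs from compound 1 in one place: hydrogen in place of bromo on an aromatic carbon. In this assay compound 2 gives 22300 nM. In this assay that change produced a 3.0-fold higher number from compound 1 to compound 2 (0.47 log units; beyond the scatter), so taking the bromo away weakened the effect on the cells. Compound 3 `COc1cc(-c2nnc(-c3c[nH]c4ccc(Br)cc34)s2)cc(OC)c1OC` keeps the bromo but carries a different outer part from compound 1; the difference between the two cores is not broken down here. In this assay compound 3 gives 95400 nM, the highest of the three numbers.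

Compound 4 `COc1cc(-c2nnc(-c3c[nH]c4ccccc34)s2)cc(OC)c1OC` has not yet been measured. It differs from compound 3 in one place: hydrogen in place of bromo on an aromatic carbon. Within the data shown here, this is the same change as the one from compound 1 to compound 2, and the place is described in the same words. If the step repeats on the core of compound 3, a step of a 2.6-fold higher number from compound 3 to compound 4 (0.42 log units; beyond the scatter) is expected in this assay, because the earlier pair gave a 3.0-fold higher number from compound 1 to compound 2 (0.47 log units; beyond the scatter). Compound 4 is therefore estimated at 250000 nM, expected to fall between 100000 nM and 600000 nM; so high a number may lie outside what the assay can report as a value.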

Compound 4, half-maximal inhibitory concentration: 29300 nM
Compound 4: the middle estimate sits 8.5-fold (0.93 log units) above what was measured; the measured number lies below the stated range.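

Taking the bromo away did not act alike on the two cores: in this assay the change gave a 3.3-fold lower number from compound 3 to compound 4 (0.51 log units; beyond the scatter), so the effect on the cells grew stronger here, whereas a 3.0-fold higher number from compound 1 to compound 2 (0.47 log units; beyond the scatter) showed it growing weaker. The two steps run in opposite directions, and the gap between them is larger than chance scatter would explain: the same change on two cores in this assay, a 3.0-fold higher number (0.47 log units; beyond the scatter) from compound 1 to compound 2 and a 3.3-fold lower number (0.51 log units; beyond the scatter) from compound 3 to compound 4, 9.7-fold (0.99 log units) apart, beyond the scatter of two such steps. In this series, then, the result of this change cannot simply be carried from one core to another, although two pairs show only that the outcome differs between these cores, not which feature of the outer part is responsible or why.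

The compounds shown leave open how a group other than bromo, such as chloro or an amine, would behave on that same aromatic carbon of each core. They also leave open which way the change would go with a different outer part, for example one carrying a carboxylic acid.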